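From 2-nitrophenyl to 4-nitrophenyl on a shared core

This account rests on a few compounds, and the source may have more. Where it says the series, first, only, none or still open, it means among the compounds named here.

In a functional assay on MCF7 cells (Homo sapiens) for antiproliferative activity, read by MTT assay, with a stated time of 48 h (a higher number here means a weaker inhibitor, a lower number a stronger inhibitor), compound 1 `CC(=O)N1N=C(c2ccc3ccccc3c2)OC1c1ccccc1` gives 2.43 ug/mL and compound 2 `CC(=O)N1N=C(c2ccc3ccccc3c2)OC1c1ccc(Cl)cc1` gives 2.63 ug/mL and the step of a 1.1-fold higher number from compound 1 to compound 2 (0.03 log units; within the scatter) leaves them level. Compound 3 `CC(=O)N1N=C(c2ccc3ccccc3c2)OC1c1ccccc1[N+](=O)[O-]` stands highest of the three at 18.2 ug/mL and is the weakest here, with a 7.5-fold higher number from compound 1 to compound 3 (0.87 log units; beyond the scatter) and a 6.9-fold higher number from compound 2 to compound 3 (0.84 log units; beyond the scatter) both lying beyond the scatter.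

Compound 4 `CC(=O)N1N=C(c2ccc3ccccc3c2)OC1c1ccc([N+](=O)[O-])cc1` is related to compound 3 by 4-nitrophenyl in place of 2-nitrophenyl on a saturated ring carbon as 4-nitrophenyl in place of 2-nitrophenyl on a saturated ring carbon. No measured pair moves a nitro group, so this step is not shown directly. Within the data shown here, compound 2 carries 4-chlorophenyl and its step of a 1.1-fold higher number from compound 1 to compound 2 (0.03 log units; within the scatter) is the only measure of a change at that place, while 2-nitrophenyl comes with the larger step of a 7.5-fold higher number from compound 1 to compound 3 (0.87 log units; beyond the scatter) in compound 3. Part of that gap is therefore expected to close, though not all of it, since a nitro group remains. The expected change is a 3.6-fold lower number from compound 3 to compound 4 (0.56 log units; beyond the scatter) towards a lower number. The estimated value for compound 4 is 5 ug/mL in an expected range from 2 ug/mL to 15 ug/mL in this assay.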

Compound 4, half-maximal inhibitory concentration: 7.59 ug/mL
The estimate for compound 4 lay 1.5-fold (0.18 log units) below the measured number, and the stated range covers the measured number.
By their numbers in this assay, from the lowest: compounds 1 and 2 (each within the scatter of the next); then compound 4; then compound 3.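

Compounds 3 and 4 have the same atoms, joined differently, yet in this assay the 2-nitrophenyl and 4-nitrophenyl groups are not interchangeable on this saturated ring carbon (a 2.4-fold lower number from compound 3 to compound 4 (0.38 log units; beyond the scatter)). Moving the nitro group does not recover the earlier level, however: the 4-nitrophenyl group still gives a higher number than the 4-chlorophenyl group (a 2.9-fold higher number from compound 2 to compound 4 (0.46 log units; beyond the scatter)) and the unsubstituted phenyl group (a 3.1-fold higher number from compound 1 to compound 4 (0.49 log units; beyond the scatter)), so both nitro compounds remain above the other two. Nothing available explains these differences.

From the compounds shown here alone, it remains open whether a 2-chlorophenyl group would differ from the 4-chlorophenyl group as the two nitrophenyl groups differ from each other. Going by these compounds, how an amine or a carboxylic acid on the same phenyl ring would compare also remains unknown.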